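The compounds below may be only part of what the source reports. "The series", "measured", "known", "first", "only" and "open" are said of these compounds alone.

Measured compounds in an ADME assay on microsomes from liver (Homo sapiens) for metabolic stability, with a stated time of 10 min; on this read-out lower numbers stand for a less stable compound and higher numbers for a more stable compound:
- compound 1, `O=C(O)C12CCC(C(=O)N3CC[C@](c4ccc(C(F)(C(F)(F)F)C(F)(F)F)cc4)(S(=O)(=O)c4ccc(F)cc4)C3)(CC1)CC2`: 100%
- compound 2, `O=C(C1CCS(=O)(=O)C1)N1CC[C@](c2ccc(C(F)(C(F)(F)F)C(F)(F)F)cc2)(S(=O)(=O)c2ccc(F)cc2)C1`: 100%; 100% (2 entries)

Compound 1 stands at the top of this read-out: in this assay compound 1 gives 100%, which is full recovery of the compound after the stated incubation. For the measured compounds named here, compound 2 sits at the same level, with 100%; 100% (2 entries) across its two entries, so the two measured members cannot be told apart on this read-out, and no step between measured compounds is available to calibrate the effect of a structural change.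

Compound 3, `O=C(N1CC[C@](c2ccc(C(F)(C(F)(F)F)C(F)(F)F)cc2)(S(=O)(=O)c2ccc(F)cc2)C1)C1(O)CCS(=O)(=O)CC1`, is not yet measured. It differs from compound 1 by a group of 9 heavy atoms (5 carbon, 3 oxygen, 1 sulfur; one six-membered non-aromatic ring with 1 hetero atom) in place of a group of 11 heavy atoms (9 carbon, 2 oxygen; 2 six-membered non-aromatic rings of carbon only), on a carbonyl carbon. With both measured compounds already at full recovery, there is no room for an upward step, and nothing in the data indicates a loss of stability for this kind of change. The expected step from compound 1 is a number 4 percentage points lower from compound 1 to compound 3 (within the scatter), that is, none beyond the usual scatter, allowing only for the ceiling of the read-out. Compound 3 is therefore estimated at 96%, with a range of 82% to 100%.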

Compound 3, percent of the compound remaining: 100%
Estimate against measurement, compound 3: 4 percentage points below; the measured number falls inside the stated range.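

In this assay, placing 4-hydroxy-1,1-dioxothian-4-yl on the carbonyl carbon, in place of the larger group with its 2 six-membered non-aromatic rings of carbon only, gives no change at the digits printed from compound 1 to compound 3 (within the scatter). For the compounds shown here, this is the first direct step at this position, and it shows that the carbon-only rings are not needed to keep the read-out unchanged: a smaller group with one hetero atom in its ring and more hydrogen-bond acceptors does as well here. The step still carries limited information, as compound 1 already shows full recovery at 100%, so only a loss could have appeared, and nothing available accounts for the result.

Open, on these data alone, is whether a different group on this carbonyl carbon, such as an amine or a longer alkyl chain, would also leave the read-out at full recovery, or whether this position can lower it at all. Also open, as far as these compounds go, is whether compound 1 and compound 3 would remain level after an incubation longer than the stated time.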